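The source may report more compounds than this note shows. Statements on the series, on what has been measured and on what is new or still open speak of the compounds shown alone.

Measured so far in an ADME assay on a cell-free system (plasma, Homo sapiens) for metabolic stability (a lower number here means that the compound disappears faster, a higher number that the compound lasts longer), are two compounds:

Compound 1 `CC(=O)N1C(=O)C(C)(C)[C@@H]2[C@@H]1CCN2C(=O)OCc1ccccc1` gives 6.5 h in this series
Compound 2 `COC(=O)N1C(=O)[C@@H](C)[C@@H]2[C@@H]1CCN2C(=O)OCc1ccccc1` gives 0.833 h in this series

Of the two, compound 2 has the lower number, and the gap to compound 1 is beyond the usual scatter. The next compound follows from compound 2 through a single change. In compound 3 `CC1CC1C(=O)N1C(=O)[C@@H](C)[C@@H]2[C@@H]1CCN2C(=O)OCc1ccccc1`, 2-methylcyclopropyl stands in place of methoxy on a carbonyl carbon 2-methylcyclopropyl in place of methoxy on a carbonyl carbon and the rest of compound 2 is unchanged.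

Within the data shown here, no measured pair in this set differs in one place only, so the size of this step has no direct precedent. Among the measured compounds shown here, the only hint is compound 1 with 6.5 h, which also has no methoxy on that carbonyl carbon, but it differs from compound 2 elsewhere too, so the hint is weak. A longer half-life is therefore expected, with the step estimated as a 3.6-fold higher number from compound 2 to compound 3 (0.56 log units; beyond the scatter) in this assay and probably beyond the scatter. For compound 3 the estimated half-life is 3 h, with an expected range from 0.8 h to 12 h and a correspondingly wide margin.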

Compound 3, half-life: 2.6 h
For compound 3 the middle estimate is 1.2-fold (0.06 log units) above the measured one; the range from low to high includes it.
By their numbers in this assay, from the lowest: compound 2; then compound 3; then compound 1.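

In this assay, among these compounds, replacing methoxy with 2-methylcyclopropyl on a carbonyl carbon gives the first step that can be read at a single place: a 3.1-fold higher number from compound 2 to compound 3 (0.49 log units; beyond the scatter), a modest change, though one beyond the scatter. It shows that this position, on a carbonyl carbon whose other neighbours are an amide-type nitrogen in a ring, affects the half-life on its own, with the rest of compound 2 unchanged. The earlier compounds shown here could not show this, since they differ in more than one place. Nothing measured here accounts for the longer half-life of compound 3.

The compounds shown leave open whether the step comes from the three-membered ring, from its methyl or simply from the departure of methoxy; a plain cyclopropyl, an ethyl or a tert-butyl on the same carbonyl carbon would help to separate these possibilities. They also leave open whether the same replacement would give a step of similar size on the core of compound 1.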